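Chain growth on the aromatic nitrogen and maximal response

The compounds below may be only part of what the source reports. "The series", "measured", "known", "first", "only" and "open" are said of these compounds alone.

Compound 3 `Cn1c(=O)n(C2OC(CO)[C@@H](O)[C@H]2O)c2nc(N)nc(O)c21` stands highest of the three measured compounds in a functional assay on the whole organism with Mus musculus as the target (on this read-out lower numbers stand for smaller maximal responses and higher numbers for larger maximal responses), with 100%. Compound 2 `CCn1c(=O)n(C2OC(CO)[C@@H](O)[C@H]2O)c2nc(N)nc(O)c21` gives 82% and compound 1 `Nc1nc(O)c2c(n1)n(C1OC(CO)[C@@H](O)[C@H]1O)c(=O)n2C/C=C/c1ccccc1` gives 5%. The step of a number 18 percentage points higher from compound 2 to compound 3 (beyond the scatter) is modest, the step of a number 95 percentage points higher from compound 1 to compound 3 (beyond the scatter) large; in both the smaller group on the saturated chain carbon bound to an aromatic nitrogen gives the larger number, a pattern resting on these three compounds only. Compound 4 `Nc1nc(O)c2c(n1)n(C1OC(CO)[C@@H](O)[C@H]1O)c(=O)n2CCN1CCCCC1` differs from compound 3 by (piperidin-1-yl)methyl in place of hydrogen on a saturated chain carbon bound to an aromatic nitrogen, a group of 7 heavy atoms, far more than the methyl of compound 2. Among the measured compounds shown here, a downward step beyond the scatter is therefore expected, a number 60 percentage points lower from compound 3 to compound 4 (beyond the scatter), its size uncertain since no measured step carries a six-membered ring with a hetero atom. Compound 4 is estimated at 40%, between 10% and 80%.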

Compound 4, largest response reached (reported as maximal response), in percent of the reference or control that the assay uses: 0%
Beside the measured number, compound 4's estimate is 40 percentage points above it; the whole stated range lies above it.
By their numbers in this assay, from the lowest: compounds 4 and 1 (each within the scatter of the next); then compound 2; then compound 3.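

Adding (piperidin-1-yl)methyl on the saturated chain carbon bound to an aromatic nitrogen leaves no measurable response: a number 100 percentage points lower from compound 3 to compound 4 (beyond the scatter) and a number 82 percentage points lower from compound 2 to compound 4 (beyond the scatter) extend the pattern of smaller group, larger number to a group with a six-membered ring carrying a hetero atom. With a number 5 percentage points lower from compound 1 to compound 4 (within the scatter) as the third step, this group and 2-phenylethenyl cannot be told apart, so response loss here does not depend on an aromatic ring in the chain. Nothing available explains the loss.

Open, on these data alone, is where the response falls away between ethyl and these large groups, for instance with a propyl chain. Also open, as far as these compounds go, is whether a morpholine ring or a dimethylamino group at the chain end behaves like the piperidine ring.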